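The source may hold more compounds than are shown below. What is called first, only, known or untested is meant among the compounds shown, and "the series" means these compounds.

Compound 1 has the structure `CC(=O)OC[C@H]1O[C@H](OC[C@@H](Cn2cc(CN(c3nc(-c4cccc([N+](=O)[O-])c4)no3)C3CCCCC3)nn2)OC(C)=O)C=C[C@@H]1OC(C)=O`; in an ADME assay on HepG2 cells (Homo sapiens) for cytotoxicity, read by MTT assay, with a stated time of 48 h (a higher number here means that more compound is tolerated, a lower number that less compound is tolerated), compound 1 gives > 200 ug/mL, which is a limit of the assay and not a number.
Compound 2 has the structure `CC(=O)OC[C@H]1O[C@H](OC[C@@H](Cn2cc(CN(c3nc(-c4ccc(C)cc4)no3)C3CCCCC3)nn2)OC(C)=O)C=C[C@@H]1OC(C)=O`; in this assay compound 2 gives 36.8 ug/mL.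
Compound 3 has the structure `CCCCCCCCCCc1cn(C[C@@H](CO[C@@H]2C=C[C@H](OC(C)=O)[C@@H](COC(C)=O)O2)OC(C)=O)nn1`; in this assay compound 3 gives 59.1 ug/mL.

Among the two numbers shown, compound 2 has the lowest, while compound 3 sits within the scatter of it; no order between compound 2 and compound 3 can be claimed. Compound 4, with the structure `CC(=O)OC[C@H]1O[C@H](OC[C@@H](Cn2cc(CN(c3nc(-c4ccc(C(F)(F)F)cc4)no3)C3CCCCC3)nn2)OC(C)=O)C=C[C@@H]1OC(C)=O`, is not yet measured. It differs from compound 2 by trifluoromethyl in place of methyl on an aromatic carbon. Among the compounds with values here, the one measured step that touches the same place is an at least 5.4-fold lower number from compound 1 to compound 2 (0.73 log units; beyond the scatter), which shows that the group on this ring can move the number by at least a modest amount. No step from a methyl to a trifluoromethyl is shown, so the direction of the change is not fixed by the data. Compound 4 is therefore expected to give about 40 ug/mL in this assay, between 15 ug/mL and 120 ug/mL, that is an expected 1.1-fold higher number from compound 2 to compound 4 (0.04 log units; within the scatter).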

Compound 4, half-maximal cytotoxic concentration: 81.4 ug/mL
Beside the measured number, compound 4's estimate is 2.0-fold (0.31 log units) below it, and the stated range covers the measured number.
By their numbers in this assay, from the lowest: compounds 2, 3 and 4 (each within the scatter of the next, the first and the last beyond it). At a limit, above all of these: compound 1.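

In this assay, trifluoromethyl in place of methyl gives a 2.2-fold higher number from compound 2 to compound 4 (0.34 log units; beyond the scatter), so a change confined to this one aromatic carbon, with the ring and the rest of the molecule untouched, is enough to move the number, and here it moves upward. Compound 4 does not close the gap to the nitro compound, since the change of 3-nitrophenyl to 4-(trifluoromethyl)phenyl gives an at least 2.4-fold lower number from compound 1 to compound 4 (0.39 log units; beyond the scatter). Compound 1 stands at a limit and not at a number, so the full size of that step stays unknown: the limit of > 200 ug/mL in this assay, at which 1 of the 4 values shown sits.

Going by these compounds, what an amine, a methoxy group or a chlorine atom on this carbon would do remains open. The compounds shown also do not tell whether compound 1 stands apart through the nitro group itself or through where that group sits on the ring.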